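Swapping Iodine for Benzofuran on a Nucleoside Core

The source may report more compounds than this note shows. Statements on the series, on what has been measured and on what is new or still open speak of the compounds shown alone.

Compound 1 `COc1ncnc2c1c(I)cn2[C@@H]1O[C@H](CO)[C@@H](O)[C@H]1O` was tested in a functional assay on K562 cells (Homo sapiens), read by MTT assay, with a stated time of 72 h; a lower number here means a stronger inhibitor, a higher number a weaker inhibitor. In this assay compound 1 gives > 20000 nM, which is a limit of the assay rather than a number. Compound 2 `Nc1nc(N)c2c(-c3ccoc3)cn([C@@H]3O[C@H](CO)[C@@H](O)[C@H]3O)c2n1` also reaches only a limit, giving > 20000 nM. Compound 3 `O=c1[nH]cnc2c1c(-c1cc3ccccc3o1)cn2[C@@H]1O[C@H](CO)[C@@H](O)[C@H]1O` likewise reaches only a limit, with > 20000 nM. Compound 1 thus stands among three compounds none of which shows a measurable number, because all three sit at the limit of > 20000 nM in this assay, at which 3 of the 3 values shown sit.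

Compound 4 `COc1ncnc2c1c(-c1cc3ccccc3o1)cn2[C@@H]1O[C@H](CO)[C@@H](O)[C@H]1O` has not yet been measured. It differs from compound 1 in one place: 1-benzofuran-2-yl in place of iodo on an aromatic carbon. For the measured compounds named here, no measured pair differs in just this way, and every compound so far stops at the limit; they give no direction for the step. Compound 3 carries the same 1-benzofuran-2-yl group and still gives only a limit. The step from compound 1 to compound 4 is expected to be a step that the limit leaves unreadable from compound 1 to compound 4, nothing beyond the scatter. Compound 4 is therefore estimated at 25000 nM, within a range from 8000 nM to 80000 nM, most likely reported again as a limit.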

Compound 4, half-maximal inhibitory concentration: 20900 nM
For compound 4 the middle estimate is 1.2-fold (0.08 log units) above the measured one; measured number inside the range.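

For the compounds shown here, compound 4 gives a measured number, but compound 1 has only a limit, so no step from compound 1 to compound 4 can be read: the limit of > 20000 nM in this assay, at which 3 of the 4 values shown sit.

In this assay the compounds shown leave open whether, and how far, 1-benzofuran-2-yl in place of iodo changes inhibition.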